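Working notes on a shared-core series, compound 4 pending

This account rests on a few compounds, and the source may have more. Where it says the series, first, only, none or still open, it means among the compounds named here.

Measured so far:
- compound 1 `Fc1ccc(-n2cc(COc3ccccc3-c3nc4ccccc4s3)nn2)cc1Cl`; in a functional assay on MCF7 cells (Homo sapiens) for cytotoxicity, read by MTT assay, with a stated time of 24 h (a higher number here means a weaker inhibitor, a lower number a stronger inhibitor), compound 1 gives 27300 nM
- compound 2 `FC(F)(F)Oc1ccc(-c2cc(COc3ccccc3-c3nc4ccccc4s3)on2)cc1`; in this assay compound 2 gives 26600 nM
- compound 3 `FC(F)(F)C(F)(F)C(F)(F)C(F)(F)C(F)(F)C(F)(F)C(F)(F)C(F)(F)CCn1cc(COc2ccccc2-c2nc3ccccc3s2)nn1`; in this assay compound 3 gives 19200 nM

Compound 2 stands second highest of the three numbers. Its nearest neighbour is compound 1, whose number lies within the scatter of it, and its furthest is compound 3, which also lies within the scatter. Within the data shown here, no two of the measured compounds differ in a single place, so no step between measured compounds is known, and nothing in these three anchors the effect of a change at the oxygen on the aromatic ring.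

Compound 4 `COc1ccc(-c2cc(COc3ccccc3-c3nc4ccccc4s3)on2)cc1` has not yet been measured. It differs from compound 2 in one place: methyl in place of trifluoromethyl on an oxygen on an aromatic ring. Among the measured compounds shown here, with no comparable step in hand and the three measured numbers spanning only a narrow band, the expected step from compound 2 to compound 4 is a 1.1-fold higher number from compound 2 to compound 4 (0.05 log units; within the scatter), with no direction claimed beyond the scatter. Compound 4 is expected to give 30000 nM in this assay, estimated within a range from 12000 nM to 75000 nM.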

Compound 4, half-maximal inhibitory concentration: 22100 nM
Beside the measured number, compound 4's estimate is 1.4-fold (0.13 log units) above it; low and high end bracket the measured number.
By their numbers in this assay, from the lowest: compounds 3, 4, 2 and 1 (each within the scatter of the next).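

Among these compounds, this is the only single-place step so far: in this assay, methyl in place of trifluoromethyl on an oxygen on an aromatic ring gives a 1.2-fold lower number from compound 2 to compound 4 (0.08 log units; within the scatter). The change from 4-(trifluoromethoxy)phenyl to 4-methoxyphenyl therefore produces no difference that can be told from the scatter, and this read-out tolerates either group at this position on the shared core. No measurement bearing on the reason for this result is available.

One pair cannot show whether a different group in this place, such as an amine, a carboxylic acid or a longer alkyl chain, would move the number beyond the scatter. It also leaves open whether the same change would give a similar step in a compound built like compound 1 or compound 3.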